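This account rests on a few compounds, and the source may have more. Where it says the series, first, only, none or still open, it means among the compounds named here.

Compound 1 `COc1ccc(OC)c(N2C(=O)CSC2c2cccc(C(=O)NCCCCc3ccccc3)c2)c1` belongs to a small set tested in a functional assay on HOS-TE85 cells (Homo sapiens) for inhibition, read by CCK-8 assay, with a stated time of 72 h; on this read-out lower numbers stand for stronger inhibition and higher numbers for weaker inhibition. For compound 1 the recorded result is only a limit of the assay, > 1000 nM. Compound 2 `COc1ccccc1N1C(=O)CSC1c1cccc(C(=O)NCCCCn2cncn2)c1`, which carries a different group on the same ring nitrogen, likewise gives only a limit, > 1000 nM. Both results therefore sit at the edge of what the assay reports (the limit of > 1000 nM in this assay, at which 2 of the 2 values shown sit). Compound 3 `C#Cc1cccc(N2C(=O)CSC2c2cccc(C(=O)NCCCCc3ccccc3)c2)c1` has not been measured. It differs from compound 1 in one place: 3-ethynylphenyl in place of 2,5-dimethoxyphenyl on an amide-type nitrogen in a ring. Within the data shown here, with no measured step to lean on, the expected change a step that the limit leaves unreadable from compound 1 to compound 3 is taken as none beyond the scatter, and compound 3 is estimated at 3000 nM, within 800 nM to 20000 nM.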

Compound 3, half-maximal inhibitory concentration: 149 nM
The estimate for compound 3 lay 20-fold (1.30 log units) above the measured number; measured number outside the range, below it.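

On an amide-type nitrogen in a ring of the shared core, replacing 2,5-dimethoxyphenyl with 3-ethynylphenyl gives, in this assay, an at least 6.7-fold lower number from compound 1 to compound 3 (0.82 log units; beyond the scatter). Among these compounds, compound 3 is the first compound here with a measured number instead of a limit, so the group at this position can clearly change the read-out. The full size of the step cannot be read: the limit of > 1000 nM in this assay, at which 2 of the 3 values shown sit.

The compounds shown do not tell whether the lower number follows the loss of the two methoxy groups or the arrival of the ethynyl group. An unsubstituted phenyl group at this position would help separate those two changes.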